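The source may report more compounds than this note shows. Statements on the series, on what has been measured and on what is new or still open speak of the compounds shown alone.

In a functional assay on MKN-28 cells (Homo sapiens) for cytotoxicity, read by MTT assay (on this read-out lower numbers stand for stronger inhibition and higher numbers for weaker inhibition), the three measured compounds stand as follows: compound 1 `C=C1C(=O)[C@]23C[C@@]1(F)CC[C@H]2[C@@]12C=CC(=O)[C@](C)(C(=O)O1)[C@H]2[C@@H]3C(=O)OC` gives 4100 nM; compound 2 `C=C1C(=O)[C@]23C[C@@]1(F)CC[C@H]2[C@@]12C=CC(=O)[C@](C)(C(=O)O1)[C@H]2[C@@H]3C(=O)OCc1ccccc1` gives 9800 nM; compound 3 `C=C1C(=O)[C@]23C[C@@]1(I)CC[C@H]2[C@@]12C=CC(=O)[C@](C)(C(=O)O1)[C@H]2[C@@H]3C(=O)OC` gives 6700 nM.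

Compound 2 differs from compound 1 by one change, (phenyl in place of hydrogen on a saturated chain carbon bound to an oxygen next to a carbonyl group). That change brought a 2.4-fold higher number from compound 1 to compound 2 (0.38 log units; beyond the scatter). Compound 3 differs from compound 1 at another site, (iodo in place of fluoro on a saturated ring carbon), and there the step was a 1.6-fold higher number from compound 1 to compound 3 (0.21 log units; within the scatter). Going by the values given here, the values of compound 2 and compound 3 lie close to each other, and no step between them is worked out here.

Compound 4 `C=C1C(=O)[C@]23C[C@@]1(I)CC[C@H]2[C@@]12C=CC(=O)[C@](C)(C(=O)O1)[C@H]2[C@@H]3C(=O)OCc1ccccc1` has not been measured in this assay. It differs from compound 3 by phenyl in place of hydrogen on a saturated chain carbon bound to an oxygen next to a carbonyl group, which is the same change as that from compound 1 to compound 2, made on the core of compound 3 rather than the core of compound 1; the two cores differ in the way described for compound 1 and compound 3. Because that change gave a 2.4-fold higher number from compound 1 to compound 2 (0.38 log units; beyond the scatter) when it was made once, the step from compound 3 to compound 4 is expected to be about a 2.4-fold higher number from compound 3 to compound 4 (0.38 log units; beyond the scatter). This rests on a single prior instance, so the expectation is loose. Compound 4 is therefore estimated to give 16000 nM in this assay. The expected range for compound 4 runs from 8000 nM to 32000 nM.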

Compound 4, half-maximal inhibitory concentration: 3000 nM
The estimate for compound 4 lay 5.3-fold (0.73 log units) above the measured number; measured number outside the range, below it.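

In this assay, the change from methoxycarbonyl to benzyloxycarbonyl brought a 2.2-fold lower number from compound 3 to compound 4 (0.35 log units; beyond the scatter), so on the iodo core it did not repeat what it had done on the fluoro core: the same change on two cores in this assay, a 2.4-fold higher number (0.38 log units; beyond the scatter) from compound 1 to compound 2 and a 2.2-fold lower number (0.35 log units; beyond the scatter) from compound 3 to compound 4, 5.3-fold (0.73 log units) apart, beyond the scatter of two such steps Read the other way, iodo in place of fluoro on a saturated ring carbon brought a 3.3-fold lower number from compound 2 to compound 4 (0.51 log units; beyond the scatter), and this step too did not match its counterpart on the core of compound 1: the same change on two cores in this assay, a 1.6-fold higher number (0.21 log units; within the scatter) from compound 1 to compound 3 and a 3.3-fold lower number (0.51 log units; beyond the scatter) from compound 2 to compound 4, 5.3-fold (0.73 log units) apart, beyond the scatter of two such steps In these four compounds, then, neither change carries over from one core to the other, and the size and direction of a step on one core gave no reliable guide to the step on the other; what the data do not show is why the two changes interact, or whether the same holds beyond this set, as each comparison rests on a single pair of steps.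

The compounds shown leave open whether chloro or bromo on the saturated ring carbon would follow the iodo or the fluoro compounds. They also leave open whether an ethoxycarbonyl group or a longer chain in place of benzyloxycarbonyl would behave as the benzyl compounds do on each core.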